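An aryloxymethyl change starting from a compound without a number

A few compounds are considered here, and "the series" means these few. Any claim that something is new, unique, unknown or untested is made for them only; others in the source may bear on it.

Measured in a functional assay on A549 cells (Homo sapiens) for inhibition, read by MTT assay, with a stated time of 48 h; on this read-out lower numbers stand for stronger inhibition and higher numbers for weaker inhibition:
compound 1 `CS(=O)(=O)Nc1ccc(-n2cc(OCc3ccccc3)nn2)cc1Oc1ccccc1` gives "not determined" (no result reported)
compound 2 `CS(=O)(=O)Nc1ccc(-n2cc(COc3ccc4ccccc4c3)nn2)cc1Oc1ccccc1` gives 8300 nM
compound 3 `CS(=O)(=O)Nc1ccc(-n2cc(COc3ccc(Cl)cc3)nn2)cc1Oc1ccccc1` gives 7100 nM

Compound 1 has no place on this scale, since no result was reported for it and it offers no number to start from. Compound 4 `CS(=O)(=O)Nc1ccc(-n2cc(COc3ccc([N+](=O)[O-])cc3)nn2)cc1Oc1ccccc1` keeps the core of compound 1 and differs in one place: (4-nitrophenoxy)methyl in place of benzyloxy on an aromatic carbon. In words, (4-nitrophenoxy)methyl stands in place of benzyloxy on an aromatic carbon. Among the compounds with values here, only one measured step bears on this change, and it bears indirectly. Compound 2 and compound 3 carry the same kind of aryloxymethyl group as the one entering here, and the step between them, a 1.2-fold lower number from compound 2 to compound 3 (0.07 log units; within the scatter), stays within the scatter. Within the data shown here, with no value for compound 1, no step from it can be sized or given a direction in this assay. The best guide is therefore the level shared by compound 2 and compound 3, though this rests on a single pair, and no shift beyond the scatter from that level is expected. Compound 4 is expected at about 7500 nM, with an estimated range from 3000 nM to 17000 nM.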

Compound 4, half-maximal inhibitory concentration: 6600 nM
Beside the measured number, compound 4's estimate is 1.1-fold (0.06 log units) above it; the range from low to high includes it.
By their numbers in this assay, from the lowest: compounds 4, 3 and 2 (each within the scatter of the next).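

In this assay the change of nitro for chloro (a 1.1-fold lower number from compound 3 to compound 4 (0.03 log units; within the scatter)) and of 4-nitrophenyl for naphthalen-2-yl (a 1.3-fold lower number from compound 2 to compound 4 (0.10 log units; within the scatter)) both stay within the scatter. The level seen for the earlier pair therefore holds for a third aryl group on the oxygen, and 4-chlorophenyl, naphthalen-2-yl and 4-nitrophenyl cannot be told apart on this read-out. No measurement at hand accounts for this sameness.

Any step from compound 1 cannot be read, so the effect of (4-nitrophenoxy)methyl in place of benzyloxy on the aromatic carbon remains unsized. Going by these compounds, it also remains open whether an amine or a carboxylic acid in place of the nitro, or a longer chain in place of the methyl link, would leave the number at this level.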